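Quinolin-8-yl in Place of Phenyl on the Sulfonyl Sulfur

The compounds below may be only part of what the source reports. "The series", "measured", "known", "first", "only" and "open" are said of these compounds alone.

Three compounds have been measured in an assay on isolated protein for inhibition of Nicotinamide phosphoribosyltransferase (Homo sapiens), read by mass spectrometry, with stated times of 15 min and 30 min; on this read-out higher numbers stand for weaker inhibition and lower numbers for stronger inhibition:

Compound 1: `N#C/N=C(\NCc1ccc(S(=O)(=O)c2ccccc2)cc1)Nc1cccnc1` gives 2.2 nM
Compound 2: `N#C/N=C(\NCc1ccc(S(=O)(=O)c2cccc(C(F)(F)F)c2)cc1)Nc1ccncc1` gives 2.4 nM
Compound 3: `N#C/N=C(\NCc1ccc(S(=O)(=O)c2ccccc2)cc1)Nc1ccncc1` gives 2.5 nM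

Compound 3 carries the highest of the three numbers, yet its gaps to compound 2 and to compound 1 are both within the scatter, so the three are indistinguishable. Compound 4, `N#C/N=C(\NCc1ccc(S(=O)(=O)c2cccc3cccnc23)cc1)Nc1ccncc1`, differs from compound 3 by quinolin-8-yl in place of phenyl on a sulfonyl sulfur. The step that bears most on this is a 1.0-fold higher number from compound 2 to compound 3 (0.02 log units; within the scatter), a change of the group on the sulfonyl sulfur that left the number flat; a 1.1-fold higher number from compound 1 to compound 3 (0.06 log units; within the scatter) touched the other end of the core and was flat as well. The new group has more heavy atoms and brings one hydrogen-bond acceptor, a larger change than either measured step, so compound 4 is expected to show a 1.6-fold higher number from compound 3 to compound 4 (0.20 log units; within the scatter), with no move beyond the scatter as the most likely outcome. Compound 4 is therefore expected to give 4 nM, within 1.5 nM to 15 nM.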

Compound 4, half-maximal inhibitory concentration: 3.6 nM
Estimate against measurement, compound 4: 1.1-fold (0.05 log units) above, and the stated range covers the measured number.
By their numbers in this assay, from the lowest: compounds 1, 2, 3 and 4 (each within the scatter of the next).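

Quinolin-8-yl on the sulfonyl sulfur gives a 1.4-fold higher number from compound 3 to compound 4 (0.16 log units; within the scatter) when it replaces phenyl, and a 1.5-fold higher number from compound 2 to compound 4 (0.18 log units; within the scatter) when it replaces 3-(trifluoromethyl)phenyl. This place on the molecule therefore takes an extra aromatic ring containing a nitrogen without a move beyond the scatter, a larger change than the earlier step at this place had tested. Nothing available here explains why the number stays within the scatter. Still open, going by these compounds, is whether a non-aromatic group on the sulfonyl sulfur, such as cyclohexyl or a short alkyl chain, would behave the same way. On these data alone, it is also open whether any group here can move the number beyond the scatter.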